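Sulfonamide chain replaced by a butyl amide on the core

This account rests on a few compounds, and the source may have more. Where it says the series, first, only, none or still open, it means among the compounds named here.

Compound 1, `CC(C)(N)C(=O)N[C@H](COCc1ccccc1)c1nnnn1CCCCCNS(C)(=O)=O`, in an assay on isolated protein for displacement of a labelled ligand from growth hormone secretagogue receptor type 1 (Homo sapiens), with a stated time of 1 h (a lower number here means a stronger inhibitor, a higher number a weaker inhibitor), gives > 5000 nM.
Compound 2, `CC(C)(N)C(=O)N[C@H](COCc1ccccc1)c1nnn(CC2Cc3ccccc3N2S(C)(=O)=O)n1`, in this assay gives > 5000 nM.
Compound 3, `CC(C)(N)C(=O)N[C@H](COCc1ccccc1)c1nnn(CCCCC#N)n1`, in this assay gives > 5000 nM.

Each of these values is a limit of the assay and not a number, so compound 1 cannot be placed above or below its two companions on the numbers shown. Where all three stand is summed up by the limit of > 5000 nM in this assay, at which 3 of the 3 values shown sit. Compound 4, `CCCCNC(=O)CCCn1nnnc1[C@@H](COCc1ccccc1)NC(=O)C(C)(C)N`, has not yet been measured. It differs from compound 1 in a single place: butylcarbamoyl in place of 2-(methanesulfonamido)ethyl on a saturated chain carbon, three bonds along the chain from an aromatic nitrogen. For the measured compounds named here, no step between measured compounds has been recorded, so there is no measured step whose size could guide this one. The three measured compounds carry different chains on the shared core, and none of them reaches a number in this assay, which gives no ground for expecting compound 4 to leave the limit. The estimated step that the limit leaves unreadable from compound 1 to compound 4 is expected to stay within the scatter. Compound 4 is estimated at 6000 nM, with a range from 1500 nM to 30000 nM.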

Compound 4, inhibition constant: 1780 nM
For compound 4 the middle estimate is 3.4-fold (0.53 log units) above the measured one; measured number inside the range.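

Swapping 2-(methanesulfonamido)ethyl for butylcarbamoyl on a saturated chain carbon, three bonds along the chain from an aromatic nitrogen, gives an at least 2.8-fold lower number from compound 1 to compound 4 (0.44 log units; beyond the scatter) in this assay. For compound 1 the value of > 5000 nM is a limit and not a number, so this step gives only a minimum size. The chain at this position can therefore bring a compound on the shared core to a readable number, which the earlier compounds did not show, and compound 4 alone does so among those shown: the limit of > 5000 nM in this assay, at which 3 of the 4 values shown sit.

The compounds shown leave open whether the amide or the butyl end of the new chain accounts for this step. On these data alone, it is also open how a shorter or longer alkyl group on the amide nitrogen, or a terminal amine or carboxylic acid on the chain, would read in this assay.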